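One Methyl on the Amine of Compound 2

A few compounds are considered here, and "the series" means these few. Any claim that something is new, unique, unknown or untested is made for them only; others in the source may bear on it.

In a functional assay on V79 cells (Cricetulus griseus) for cytotoxicity, read by colony formation (a higher number here means a weaker inhibitor, a lower number a stronger inhibitor), compound 2 `COc1c(N2CCC(C)(CN)C2)c(F)cc2c(=O)c(C(=O)O)cn(C3CC3)c12` reads 38 ug/mL, against compound 1 `CC1(CN)CCN(c2cc3c(cc2F)c(=O)c(C(=O)O)cn3C2CC2)C1` at 23 ug/mL and compound 3 `CC1(CN)CCN(c2c(F)cc3c(=O)c(C(=O)O)cn(C4CC4)c3c2C(F)(F)F)C1` at 110 ug/mL in the same test. The gap at the low end is small (a 1.7-fold higher number from compound 1 to compound 2 (0.22 log units; within the scatter)) and the gap at the top is larger (a 2.9-fold higher number from compound 2 to compound 3 (0.46 log units; beyond the scatter)). Compound 4 `CNCC1(C)CCN(c2c(F)cc3c(=O)c(C(=O)O)cn(C4CC4)c3c2OC)C1` differs from compound 2 by methyl in place of hydrogen on an amine nitrogen. The widest measured step (a 4.8-fold higher number from compound 1 to compound 3 (0.68 log units; beyond the scatter)) and the other two all change a group on an aromatic carbon, so none of them tests this amine change directly. No shift beyond the scatter is therefore expected in this assay, and the expected step is no change at the digits printed from compound 2 to compound 4 (within the scatter) at most loosely known. Compound 4 is estimated at 38 ug/mL with 15 ug/mL to 95 ug/mL as the expected range.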

Compound 4, half-maximal inhibitory concentration: 120 ug/mL
Beside the measured number, compound 4's estimate is 3.2-fold (0.50 log units) below it, and the stated range ends below it.
By their numbers in this assay, from the lowest: compounds 1 and 2 (each within the scatter of the next); then compounds 3 and 4 (each within the scatter of the next).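

Among the compounds shown here, the earlier steps all changed a group on an aromatic carbon, so this is the first sign that the amine nitrogen matters in this assay. Going from aminomethyl to (methylamino)methyl gives a 3.2-fold higher number from compound 2 to compound 4 (0.50 log units; beyond the scatter), so one methyl on this nitrogen is enough to make the compound a weaker inhibitor in this test. Nothing available explains this shift.

From the compounds shown here alone, whether ethyl on the same nitrogen, or a dimethylamino group, would move the number further remains open. So does whether the same methyl would give a similar step on compound 1 or compound 3.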